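The compounds below may be only part of what the source reports. "The series", "measured", "known", "first", "only" and "open" are said of these compounds alone.

Working notes on the series, all read in a functional assay on A549 cells (Homo sapiens) for cytotoxicity, read by MTT assay, with a stated time of 48 h; a higher number here means a weaker inhibitor, a lower number a stronger inhibitor. Compound 1 (`CCOC(=O)[C@@]1(C(=O)Nc2ccccc2)C[C@@H]1c1cc(OC)c(OC)c(OC)c1`) gives > 100000 nM. That entry is a limit of the assay and not a number, so compound 1 offers no exact starting point. Compound 2 (`CCOC(=O)C1(C(=O)Nc2ccc(OC)cc2)CC1c1cc(OC)c(OC)c(OC)c1`) gives 61400 nM; > 100000 nM (2 entries).

The next compound to be read is compound 3 (`CCOC(=O)[C@]1(C(=O)Nc2ccccc2)C[C@@H]1c1cc(OC)c(OC)c(OC)c1`), the stereo partner of compound 1: the two compounds have the same atoms and bonds and differ only in configuration as drawn: 1 of 2 stereo elements differ; a stereocentre at a saturated ring carbon is drawn S in compound 1 and R in compound 3. Among the compounds with values here, no measured pair shows what a change of configuration does here, so no precedent supports a large step. The working expectation is none beyond the scatter, with no direction favoured. Within the data shown here, the only guide to the level is compound 2 at 61400 nM; > 100000 nM (2 entries), and this places the expectation close to the top of the measurable range. The estimated a number no higher from compound 1 to compound 3 (the limit leaves the size open) is therefore expected to be small. For compound 3 the expected value is 100000 nM, with an estimated range of 40000 nM to 200000 nM. A report of a limit only, rather than a number, is the likelier outcome.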

Compound 3, half-maximal inhibitory concentration: 21300 nM
The estimate for compound 3 lay 4.7-fold (0.67 log units) above the measured number; measured number below the stated range.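

In this assay the series now shows an at least 4.6-fold lower number from compound 1 to compound 3 (0.67 log units; beyond the scatter), the first measured effect of configuration, here at a stereocentre at a saturated ring carbon drawn S in compound 1 and R in compound 3. On these data alone, compound 1 gives > 100000 nM, which is a limit of the assay and not a number, so the true size of this step stays open beyond its printed lower bound. The step can be assigned to configuration at this one stereocentre alone, because no atom or bond enters or leaves between the two structures: the fact that compounds 1 and 3 differ only in the configuration as drawn

Compound 2 is drawn without configuration, so the compounds shown do not tell whether the same preference for the R form holds when a methoxy group is present on the anilide ring, nor what the second stereocentre contributes when its configuration is changed. Also open, as far as these compounds go, is whether the gap between the two configurations survives a change elsewhere in the core, such as a carboxylic acid in place of the ethyl ester.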